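The source may hold more compounds than are shown below. What is called first, only, known or untested is meant among the compounds shown, and "the series" means these compounds.

Measured so far in an assay on T-REx-293 cells for inhibition of potassium channel subfamily T member 1 (Homo sapiens), read by patch clamp; on this read-out lower numbers stand for stronger inhibition and higher numbers for weaker inhibition:
- compound 1, `C[C@H](NC(=O)c1cc(C(F)(F)F)nn1C)c1nc(-c2ccncc2)no1`: 5250 nM
- compound 2, `C[C@H](NC(=O)c1cc(C(F)(F)F)nn1C)c1nc(-c2cnn(C)c2)no1`: 2640 nM
- compound 3, `C[C@H](NC(=O)c1cc(C(F)(F)F)nn1C)c1nc(-c2ccnc(N(C)C)c2)no1`: 454 nM

Compound 3 gives the lowest number of the three in this assay. Its nearest neighbour is compound 2, as the step of a 5.8-fold lower number from compound 2 to compound 3 (0.76 log units; beyond the scatter) shows, and the widest gap is to compound 1, as the step of a 12-fold lower number from compound 1 to compound 3 (1.06 log units; beyond the scatter) shows; both steps lie beyond the scatter. The step of a 2.0-fold lower number from compound 1 to compound 2 (0.30 log units; within the scatter) stays within the scatter.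

Compound 4, `C[C@H](NC(=O)c1cc(C(F)(F)F)nn1C)c1nc(-c2ccnc(C(F)(F)F)c2)no1`, has not been measured. It differs from compound 3 in one place: trifluoromethyl in place of dimethylamino on an aromatic carbon. Going by the values given here, the step that bears most directly on this change is the one from compound 1 to compound 3, where dimethylamino in place of hydrogen on that aromatic carbon gave a 12-fold lower number from compound 1 to compound 3 (1.06 log units; beyond the scatter). Among the compounds with values here, compound 4 gives up the dimethylamino that this step rewarded and takes trifluoromethyl instead, a group no measured compound carries, so its result is expected to move back toward compound 1. An estimated step of a 6.6-fold higher number from compound 3 to compound 4 (0.82 log units; beyond the scatter) is expected in this assay, toward a higher number. Compound 4 is therefore estimated at 3000 nM, with a range from 800 nM to 12000 nM.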

Compound 4, half-maximal inhibitory concentration: 40 nM
Beside the measured number, compound 4's estimate is 75-fold (1.88 log units) above it, and the stated range ends above it.
By their numbers in this assay, from the lowest: compound 4; then compound 3; then compounds 2 and 1 (each within the scatter of the next).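

In this assay, the gain at this carbon next to the ring nitrogen does not depend on dimethylamino: trifluoromethyl, which has no hydrogen-bond acceptor by the count given, goes well past it (with an 11-fold lower number from compound 3 to compound 4 (1.05 log units; beyond the scatter)), so the acceptor that dimethylamino brings is not needed for a low number here. Both groups improve on the unsubstituted pyridin-4-yl, but the return is far greater with trifluoromethyl (with a 130-fold lower number from compound 1 to compound 4 (2.12 log units; beyond the scatter), against a 12-fold lower number from compound 1 to compound 3 (1.06 log units; beyond the scatter)), and the 2-(trifluoromethyl)pyridin-4-yl group also stands well clear of the 1-methyl-1H-pyrazol-4-yl group (with a 66-fold lower number from compound 2 to compound 4 (1.82 log units; beyond the scatter)). Nothing among the data shown explains why trifluoromethyl does so much better at this position.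

Going by these compounds, what remains open is whether the low number belongs to trifluoromethyl itself or would also come with a chlorine, a nitrile or a plain methyl on this same carbon. On these data alone, it is also open whether trifluoromethyl would give a similar result on the other carbons of this six-membered aromatic ring.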